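Removing the bromo group from compound 2

A few compounds are considered here, and "the series" means these few. Any claim that something is new, unique, unknown or untested is made for them only; others in the source may bear on it.

Compound 1 `Brc1cccc(CSc2nnc(-c3cnccn3)n2-c2ccccc2)c1`: 9580 nM
Compound 2 `Brc1ccc(CSc2nnc(-c3cnccn3)n2-c2ccccc2)cc1`: 8630 nM

Both values come from a functional assay on HeLa cells (Homo sapiens) for antiproliferative activity, read by MTT assay, with a stated time of 48 h; on this read-out higher numbers stand for weaker inhibition and lower numbers for stronger inhibition. For the measured compounds named here, the only measured step is a 1.1-fold lower number from compound 1 to compound 2 (0.05 log units; within the scatter), and it lies within the scatter, so compound 2 stands level with compound 1 on these numbers. The next change leads to compound 3 `c1ccc(CSc2nnc(-c3cnccn3)n2-c2ccccc2)cc1`: hydrogen in place of bromo on an aromatic carbon. The measured step bears on this only indirectly, since both of its compounds keep the bromo group. Going by the values given here, it shows that shifting bromo changed little, but no measured compound lacks bromo. In this assay a small step is therefore expected, with a slightly higher number as a tentative direction. The expected step is a 1.3-fold higher number from compound 2 to compound 3 (0.11 log units; within the scatter). For compound 3 the estimated value is 11000 nM, with an expected range from 4500 nM to 27000 nM.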

Compound 3, half-maximal inhibitory concentration: 35600 nM
Compound 3: the middle estimate sits 3.2-fold (0.51 log units) below what was measured, outside the stated range (above it).
By their numbers in this assay, from the lowest: compounds 2 and 1 (each within the scatter of the next); then compound 3.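

In this assay, the presence of a bromo group proves to count for more than where it sits: replacing it with hydrogen gives a 4.1-fold higher number from compound 2 to compound 3 (0.62 log units; beyond the scatter), and the same replacement measured against the other bromo compound gives a 3.7-fold higher number from compound 1 to compound 3 (0.57 log units; beyond the scatter). Both steps lie beyond the scatter, so either bromo compound outperforms the plain benzyl compound, even though moving bromo between the two places made no readable difference. Nothing available explains why this replacement weakens inhibition.

Going by these compounds, it remains open whether this gain is specific to bromo or would also come from chloro, methyl or methoxy at the same place on the ring. It is equally unclear how an amine or a carboxylic acid there would compare with either bromo or hydrogen.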